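Removing an Isopropyl Group: Expected Cytotoxicity of Compound 3

This account rests on a few compounds, and the source may have more. Where it says the series, first, only, none or still open, it means among the compounds named here.

Measured compounds:
Compound 1, `CC(C)Oc1cccc(-c2ccc(C(=O)N(Cc3cccc(OCCCCCC(=O)O)c3)C(C)C)cc2)c1`: in an ADME assay on HepG2 cells (Homo sapiens) for cytotoxicity, read by CellTiter-Glo and resazurin assay, with a stated time of 72 h (a higher number here means that more compound is needed for the effect, a lower number that less compound is needed), compound 1 gives > 26000 nM, which is a limit of the assay and not a number.
Compound 2, `CCOC(=O)CCCCCOc1cccc(CN(C(=O)c2ccc(-c3cccc(OC(C)C)c3)cc2)C(C)C)c1`: in this assay compound 2 gives > 26000 nM, also a limit of the assay rather than a number.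

Compound 2 therefore stands at the highest concentration the assay can report, with no measurable cytotoxicity below it. The step that the two limits leave unreadable from compound 1 to compound 2 cannot be read because both of its ends sit at the limit described by the limit of > 26000 nM in this assay, at which 2 of the 2 values shown sit.

Compound 3, `CCOC(=O)CCCCCOc1cccc(CN(C(=O)c2ccc(-c3cccc(O)c3)cc2)C(C)C)c1`, differs from compound 2 in one place: hydrogen in place of isopropyl on an oxygen on an aromatic ring. No measured step touches this change, and the only step shown concerns a different position and is itself unreadable. There is thus no evidence that this change moves cytotoxicity out of the range seen so far.

On that basis compound 3 is expected to remain at the limit in this assay, giving an estimated 26000 nM with a range from 13000 nM to 52000 nM. The expected step is a number no higher from compound 2 to compound 3 (the limit leaves the size open), essentially none.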

Compound 3, half-maximal effective concentration: > 26000 nM
Compound 3: only a limit was reported; the forecaster's own chance of this, stated with the estimate: 80%; the middle value sits exactly at the limit.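

In this assay compound 3 gives > 26000 nM as a limit and not a number. The step from compound 2 to compound 3 therefore cannot be read, because the values share one limit: the limit of > 26000 nM in this assay, at which 3 of the 3 values shown sit. The compounds shown leave open at what concentration compound 2 or compound 3 would show cytotoxicity, and whether going from 3-isopropoxyphenyl to 3-hydroxyphenyl shifts that concentration.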